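The compounds below may be only part of what the source reports. "The series", "measured", "known", "first", "only" and "open" are said of these compounds alone.

Among the measured compounds shown here, compound 2 `CCCCN(CCCC)CCCCCOc1ccc(C(=O)/C=C/c2ccccc2)cc1` stands highest of the two numbers so far: in a physicochemical assay for lipophilicity, using the shake flask method, measured as octanol-water partition, at pH 7.4 (a lower number here means a more polar compound, a higher number a more lipophilic compound), compound 2 gives 2.14, while compound 1 `CN(C)CCCCCOc1ccc(C(=O)/C=C/c2ccccc2)cc1` gives 1.73. For the measured compounds named here, the only measured step, a number 0.41 log units higher from compound 1 to compound 2 (beyond the scatter), came from enlarging the alkyl groups on the amine nitrogen. Compound 3 `CCCCN(CCCC)CCCCCCOc1ccc(C(=O)/C=C/c2ccccc2)cc1` differs from compound 2 in a related but smaller way: (dibutylamino)methyl in place of dibutylamino on a saturated chain carbon, five bonds along the chain from an oxygen on an aromatic ring. Since that single extra chain carbon is a far smaller addition of saturated carbon than the one measured, compound 3 is expected to rise by only a number 0.31 log units higher from compound 2 to compound 3 (beyond the scatter), possibly within the scatter. Compound 3 is therefore estimated at 2.45, between 2.1 and 2.85.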

Compound 3, partition coefficient: 2.19
Compound 3: middle estimate off by 0.26 log units, on the high side; the measured number falls inside the stated range.
By their numbers in this assay, from the lowest: compound 1; then compounds 2 and 3 (each within the scatter of the next).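

In this assay, (dibutylamino)methyl in place of dibutylamino gives a number 0.05 log units higher from compound 2 to compound 3 (within the scatter) and so, at this position, the added chain carbon makes no readable difference. Measured against the dimethylamino end, (dibutylamino)methyl gives a number 0.46 log units higher from compound 1 to compound 3 (beyond the scatter) as a modest step, the only one of the two new steps beyond the scatter. No available evidence accounts for these numbers. The compounds shown leave open whether a much longer chain would give a step beyond the scatter, and how a cyclic amine such as piperidine would compare with dibutylamino.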